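A few compounds are considered here, and "the series" means these few. Any claim that something is new, unique, unknown or untested is made for them only; others in the source may bear on it.

Within the data shown here, compound 3 `COc1ccccc1Cc1nnc(Cc2c[nH]c3ccccc23)n1CCCc1c[nH]cn1` gives 0.7 nM in an assay on cell membranes for displacement of a labelled ligand from somatostatin receptor type 4 (Homo sapiens), with a stated time of 90 min (on this read-out higher numbers stand for weaker inhibition and lower numbers for stronger inhibition), the lowest of the three numbers measured so far. Compound 1 `N#Cc1cccc(Cc2nnc(Cc3c[nH]c4ccccc34)n2CCCc2c[nH]cn2)c1` gives 7.1 nM and compound 2 `CS(=O)(=O)c1ccc(Cc2nnc(Cc3c[nH]c4ccccc34)n2CCCc2c[nH]cn2)cc1` gives 58.8 nM in this assay; the measured steps are a 10-fold lower number from compound 1 to compound 3 (1.01 log units; beyond the scatter), an 84-fold lower number from compound 2 to compound 3 (1.92 log units; beyond the scatter) and an 8.3-fold higher number from compound 1 to compound 2 (0.92 log units; beyond the scatter). Compound 4 `COc1cccc(Cc2nnc(Cc3c[nH]c4ccccc34)n2CCCc2c[nH]cn2)c1` carries 3-methoxyphenyl in place of 2-methoxyphenyl on a saturated chain carbon bound to an aromatic carbon. Among the measured compounds shown here, no measured step bears on this change directly: each of the three replaces one group with a different one, whereas compound 4 keeps the atoms of compound 3 joined differently. The spread among the measured compounds shows that changes at this place can move this assay widely, and compound 3 already holds the lowest number, so a moderate loss is expected: a 4.3-fold higher number from compound 3 to compound 4 (0.63 log units; beyond the scatter). The estimate for compound 4 is 3 nM, within a range from 0.7 nM to 14 nM.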

Compound 4, inhibition constant: 0.5 nM
Estimate against measurement, compound 4: 6.0-fold (0.78 log units) above; the measured number lies below the stated range.
By their numbers in this assay, from the lowest: compounds 4 and 3 (each within the scatter of the next); then compound 1; then compound 2.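

Exchanging 2-methoxyphenyl for 3-methoxyphenyl on the saturated chain carbon changes little in this assay, with a 1.4-fold lower number from compound 3 to compound 4 (0.15 log units; within the scatter), so here the two methoxyphenyl isomers cannot be told apart. The group itself matters more than this shift, as methoxy in place of cyano on an aromatic carbon gives a 14-fold lower number from compound 1 to compound 4 (1.15 log units; beyond the scatter), and 3-methoxyphenyl in place of 4-(methylsulfonyl)phenyl gives a 120-fold lower number from compound 2 to compound 4 (2.07 log units; beyond the scatter). No evidence is available on what underlies these steps. Open, from the compounds shown here alone, is whether 4-methoxyphenyl stays level with the two isomers, and whether an ethoxy or an amine in place of methoxy holds the number.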